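Replacing 3,5-dichlorophenyl with 5-chloro-1H-indol-3-yl

The source may hold more compounds than are shown below. What is called first, only, known or untested is meant among the compounds shown, and "the series" means these compounds.

In a functional assay on DU-145 cells (Homo sapiens) for inhibition, read by trypan blue exclusion, with a stated time of 96 h (a lower number here means a stronger inhibitor of growth, a higher number a weaker inhibitor of growth), compound 3 (`Cc1ccc(CS/C(=C/c2cc(Cl)cc(Cl)c2)C(=O)c2ccc(Cl)cc2)cc1`) gives 10000 nM. This is level with compound 1 (`Cc1ccc(CS/C(=C/c2cc(C)ccc2C)C(=O)c2ccc(Cl)cc2)cc1`), which gives 10000 nM, and the two share the highest number of the three measured. Compound 2 (`Cc1ccc(S/C(=C/c2c[nH]c3ccc(Cl)cc23)C(=O)c2ccc(Cl)cc2)cc1`) gives 1000 nM, a lower number that lies beyond the scatter from compound 3.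

Compound 4 (`Cc1ccc(CS/C(=C/c2c[nH]c3ccc(Cl)cc23)C(=O)c2ccc(Cl)cc2)cc1`) differs from compound 3 at one place: 5-chloro-1H-indol-3-yl in place of 3,5-dichlorophenyl on a double-bonded chain carbon bound to a double-bonded chain carbon. Among the measured compounds shown here, the only measured step at that place, no change at the digits printed from compound 1 to compound 3 (within the scatter), exchanged 2,5-dimethylphenyl for 3,5-dichlorophenyl and does not test the incoming group. The expectation of a lower number in this assay rests on compound 2, which carries 5-chloro-1H-indol-3-yl and gives 1000 nM. That evidence is indirect, since compound 2 differs from compound 4 elsewhere in the structure. The expected change is a 6.7-fold lower number from compound 3 to compound 4 (0.82 log units; beyond the scatter), and it remains uncertain. For compound 4 the estimated value is 1500 nM, with an expected range of 300 nM to 7000 nM.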

Compound 4, concentration for 50% growth inhibition: 1000 nM
Beside the measured number, compound 4's estimate is 1.5-fold (0.18 log units) above it; the measured number falls inside the stated range.
By their numbers in this assay, from the lowest: compounds 2 and 4 (each within the scatter of the next); then compounds 1 and 3 (each within the scatter of the next).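

In this assay, 5-chloro-1H-indol-3-yl gives a step that the earlier exchange of two substituted phenyl groups did not: there the change was no change at the digits printed from compound 1 to compound 3 (within the scatter), whereas here the change is a 10-fold lower number from compound 3 to compound 4 (1.00 log units; beyond the scatter), and against the other phenyl group it is a 10-fold lower number from compound 1 to compound 4 (1.00 log units; beyond the scatter). This position therefore responds to the group it carries, at least for these three groups on this core. The change on the sulfur gives no change at the digits printed from compound 2 to compound 4 (within the scatter), so with 5-chloro-1H-indol-3-yl in place, 4-methylbenzyl and 4-methylphenyl cannot be told apart in this assay.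

Nothing measured here accounts for the step at this position. Still open, going by these compounds, is how an unsubstituted indol-3-yl, a 1-methylindol-3-yl or a pyridyl group would fare at this position, and how a longer chain ending in an amine would fare on the sulfur.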